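Swapping the acetamide heteroaryl on a shared core

The compounds below may be only part of what the source reports. "The series", "measured", "known", "first", "only" and "open" are said of these compounds alone.

Compound 1 `CCOc1ncc(-c2nc(C(F)(F)F)sc2N2CCN(C(=O)Cn3ccc4cccnc43)[C@H](C)C2)cn1` — 47 nM
Compound 2 `CCOc1ncc(-c2nc(C(F)(F)F)sc2N2CCN(C(=O)Cn3c(=O)oc4ccccc43)[C@H](C)C2)cn1` — 536 nM

Both compounds share one core and differ only in the aromatic group on the saturated chain carbon bound to the carbonyl carbon. In an assay on blood for inhibition of C-X-C chemokine receptor type 3 (Homo sapiens), with a stated time of 30 min (on this read-out lower numbers stand for stronger inhibition and higher numbers for weaker inhibition), compound 2 gives 536 nM, the higher of the two numbers; the step of an 11-fold higher number from compound 1 to compound 2 (1.06 log units; beyond the scatter) shows that this group alone moves the result well beyond the scatter.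

Compound 3 `CCOc1ncc(-c2nc(C(F)(F)F)sc2N2CCN(C(=O)Cn3nc(C)nc3C)[C@H](C)C2)cn1` carries a further replacement at the same place: a group of 7 heavy atoms (4 carbon, 3 nitrogen; one five-membered aromatic ring with 3 hetero atoms) in place of a group of 10 heavy atoms (7 carbon, 1 nitrogen, 2 oxygen; one five-membered aromatic ring with 2 hetero atoms, one six-membered aromatic ring of carbon only), on a saturated chain carbon bound to a carbonyl carbon. Within the data shown here, only the step from compound 1 to compound 2 bears on this change, and it was large, so a sizeable shift is plausible, though its direction for a new group cannot be read from a single step. Compound 3 is therefore expected to fall between the two measured compounds, its number expected to move by a 2.7-fold lower number from compound 2 to compound 3 (0.43 log units; beyond the scatter). For compound 3 the estimate in this assay is 200 nM, within a range of 50 nM to 800 nM.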

Compound 3, half-maximal inhibitory concentration: 364 nM
Compound 3: middle estimate off by 1.8-fold (0.26 log units), on the low side; the range from low to high includes it.
By their numbers in this assay, from the lowest: compound 1; then compounds 3 and 2 (each within the scatter of the next).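

In this assay, replacing the two-ring group at this place with the single-ring 3,5-dimethyl-1H-1,2,4-triazol-1-yl leaves the read-out unresolved, with a 1.5-fold lower number from compound 2 to compound 3 (0.17 log units; within the scatter), so the two groups cannot be told apart despite their different ring counts. The gap to the group of compound 1 remains, with a 7.7-fold higher number from compound 1 to compound 3 (0.89 log units; beyond the scatter), and compound 1 is now the strongest of the three, its two-ring group standing apart from both a two-ring and a single-ring replacement, so ring count alone does not sort these compounds. Nothing available here accounts for why the group of compound 1 stands apart.

The compounds shown leave open how a plain phenyl ring or a dimethylamino group would read on this saturated chain carbon bound to a carbonyl carbon. They also leave open whether such a group would fall nearer compound 1 or nearer compound 2 and compound 3.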